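The source may hold more compounds than are shown below. What is called first, only, known or untested is meant among the compounds shown, and "the series" means these compounds.

Of the compounds shown here, two of a shared core have been measured in an ADME assay for permeability, using PAMPA, with a stated time of 4 h; a lower number here means that the compound crosses the layer more slowly, a higher number that the compound crosses the layer faster. Compound 1, `Cc1ccc(Oc2ccc3nc(COc4cccc(C(=O)O)c4)n(C)c3n2)cc1`, gives 12.6 10^-6 cm/s in this assay. Compound 2, `Cn1c(COc2cccc(C(=O)O)c2)nc2ccc(Oc3cccc(Cl)n3)cc21`, gives 7.6 10^-6 cm/s. Where compound 2 stands is easy to say: it and compound 1 lie within the usual scatter of each other, so the two numbers cannot be told apart.

Compound 3, `Cn1c(COc2cccc(C(=O)O)c2)nc2ccc(Oc3cc(Cl)ccn3)cc21`, has not been measured yet. It differs from compound 2 in one place: 4-chloropyridin-2-yl in place of 6-chloropyridin-2-yl on an oxygen on an aromatic ring. The two structures hold the same atoms, joined differently, so the chlorine merely sits elsewhere on the same ring.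

Among the measured compounds shown here, no measured pair in this set shows a change of this kind, so there is no step to lean on. With only a rearrangement of the same atoms, the expected step from compound 2 to compound 3 is a 1.1-fold higher number from compound 2 to compound 3 (0.02 log units; within the scatter), that is, nothing beyond the scatter. Compound 3 is therefore estimated at 8 10^-6 cm/s, with a range from 4.5 10^-6 cm/s to 14 10^-6 cm/s.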

Compound 3, apparent permeability: 10.3 10^-6 cm/s
Compound 3: the middle estimate sits 1.3-fold (0.11 log units) below what was measured; measured number inside the range.
By their numbers in this assay, from the lowest: compounds 2, 3 and 1 (each within the scatter of the next).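

In this assay, among the compounds shown here, putting 4-chloropyridin-2-yl in place of 6-chloropyridin-2-yl on an oxygen on an aromatic ring gives a 1.4-fold higher number from compound 2 to compound 3 (0.13 log units; within the scatter), the first step in this set between compounds that differ in one place. For this position, the step shows that these two placements of the chlorine cannot be told apart in this read-out. No measurement shown here bears on this result.

Still open, from the compounds shown here alone, is whether a different group on this pyridine ring, such as an amine or a methoxy group, would give a step beyond the scatter. Compound 1 differs from compound 2 and compound 3 in more than one place, so it cannot answer that, and an amide in place of the carboxylic acid also remains untested among the compounds shown.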